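From compound 3 to compound 4: one ring exchange

The source may report more compounds than this note shows. Statements on the series, on what has been measured and on what is new or still open speak of the compounds shown alone.

Compounds measured in a functional assay on HCT-116 cells (Homo sapiens) for antiproliferative activity, read by MTT assay, with a stated time of 48 h (on this read-out lower numbers stand for stronger inhibition and higher numbers for weaker inhibition), so far
compound 1 `COc1ccc(-c2cncc3[nH]c(=O)n(Cc4cc(OC)c(OC)c(OC)c4)c23)cc1O` gives > 20000 nM as a limit
compound 2 `COc1ccc(-c2cncc3[nH]c(=O)n(Cc4cc(OC)c(OC)c(OC)c4)c23)cc1` gives > 20000 nM as a limit
compound 3 `COc1ccc(-c2cc3c(cn2)[nH]c(=O)n3-c2cc(OC)c(OC)c(OC)c2)cc1F` gives 910 nM as a number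

Going by the values given here, compound 3 holds the only number in the set, and the other two values are limits. Compound 4 `COc1ccc(-c2cc3c(cn2)[nH]c(=O)n3-c2cc(OC)c(OC)c(OC)c2)cn1` differs from it in one place: 6-methoxypyridin-3-yl in place of 3-fluoro-4-methoxyphenyl on an aromatic carbon in words, 6-methoxypyridin-3-yl in place of 3-fluoro-4-methoxyphenyl on an aromatic carbon. Among the compounds with values here, the sole measured step, a step that the two limits leave unreadable from compound 1 to compound 2, concerns another group, so no measured step sizes this change. Starting from compound 3 at 910 nM, a modest weakening in this assay is expected, held loosely, and a 2.0-fold higher number from compound 3 to compound 4 (0.30 log units; within the scatter) is the estimated step. For compound 4 the estimate is 1800 nM, with an expected range from 350 nM to 12000 nM as the outer end.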

Compound 4, half-maximal inhibitory concentration: 830 nM
Compound 4: the middle estimate sits 2.2-fold (0.34 log units) above what was measured; the measured number falls inside the stated range.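

In this assay, replacing 3-fluoro-4-methoxyphenyl with 6-methoxypyridin-3-yl gives a 1.1-fold lower number from compound 3 to compound 4 (0.04 log units; within the scatter). Going by these compounds alone, at this position, next to the ring nitrogen, the fluorine-bearing carbon ring and the methoxypyridine thus cannot be told apart, which the earlier compounds could not show. Nothing measured here bears on a cause for this result.

Within the data shown here, the single exchange does not separate the loss of fluorine from the entry of the ring nitrogen. Going by these compounds, how an amine or a carboxylic acid on this ring would read remains open.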